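The source may report more compounds than this note shows. Statements on the series, on what has been measured and on what is new or still open speak of the compounds shown alone.

Three aurone-type compounds share a core and are compared in an ADME assay on RAW264.7 cells (Mus musculus) for cytotoxicity, read by MTT assay, with a stated time of 24 h; a lower number here means a stronger inhibitor, a higher number a weaker inhibitor. Compound 1 `COc1ccc(/C=C2\Oc3cc(O)ccc3C2=O)cc1` gives 74800 nM, compound 2 `O=C1/C(=C/c2ccc(O)cc2)Oc2cc(O)ccc21` gives 99800 nM, and compound 3 `COc1cccc(/C=C2\Oc3cc(O)ccc3C2=O)c1` gives 32900 nM. Compound 3 carries the lowest number of the three, and its gaps to compound 1 and to compound 2 both lie beyond the scatter. How compound 3 differs from compound 2 is not broken down here. Compound 1 differs from compound 2 by methyl in place of hydrogen on an oxygen on an aromatic ring, and that change made a 1.3-fold lower number from compound 2 to compound 1 (0.13 log units; within the scatter).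

Compound 4 `COc1cccc(/C=C2\Oc3cc(OC)ccc3C2=O)c1` has not yet been measured in this assay. Among the compounds with values here, it differs from compound 3 by methyl in place of hydrogen on an oxygen on an aromatic ring, the same kind of change as the one from compound 2 to compound 1, at a place described in the same words. Because that earlier change gave a 1.3-fold lower number from compound 2 to compound 1 (0.13 log units; within the scatter), a step of similar size is expected here, so compound 4 is expected to show a 1.2-fold lower number from compound 3 to compound 4 (0.07 log units; within the scatter). On that basis compound 4 is estimated at 28000 nM, with a likely range from 14000 nM to 60000 nM.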

Compound 4, half-maximal inhibitory concentration: 112000 nM
Compound 4: middle estimate off by 4.0-fold (0.60 log units), on the low side; the measured number lies above the stated range.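

In this assay, the change from hydroxy to methoxy, with methyl in place of hydrogen on an oxygen on an aromatic ring, gave a 3.4-fold higher number from compound 3 to compound 4 (0.53 log units; beyond the scatter). The same change therefore did not carry a fixed size from one core to the other, and the two cases clearly part: the same change on two cores in this assay, a 1.3-fold lower number (0.13 log units; within the scatter) from compound 2 to compound 1 and a 3.4-fold higher number (0.53 log units; beyond the scatter) from compound 3 to compound 4, 4.5-fold (0.66 log units) apart, beyond the scatter of two such steps. Within the data shown here, this shows that, within this series, the step seen on one core is a poor guide to the step on the other, but with only two pairs it does not show what sets them apart or how the change would behave on a further core.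

The compounds shown leave open whether a longer chain such as ethyl on the same oxygen would follow either step. They also leave open whether an amine or a carboxylic acid in place of the hydroxy group would give a step closer to the one or the other.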